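This account rests on a few compounds, and the source may have more. Where it says the series, first, only, none or still open, it means among the compounds named here.

In a functional assay on HepG2 cells (Homo sapiens) for cytotoxicity, read by MTT assay, with a stated time of 72 h (on this read-out higher numbers stand for weaker inhibition and lower numbers for stronger inhibition), compound 3 `Cc1ccc(-c2nc3cc(NC(=O)CN4CCCCC4)ccc3[nH]2)cc1` gives > 50000 nM, which is a limit of the assay and not a number. Compound 1 `Cc1ccc(-c2nc3cc(NC(=O)CN4CCN(C)CC4)ccc3[nH]2)cc1` gives > 50000 nM, also a limit. Compound 2 `CCN1CCN(CC(=O)Nc2ccc3[nH]c(-c4cccn4C)nc3c2)CC1` gives > 50000 nM, again a limit. The evidence so far is therefore (the limit of > 50000 nM in this assay, at which 3 of the 3 values shown sit).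

Compound 4 `CCN1CCN(CC(=O)Nc2ccc3[nH]c(-c4ccc(C)cc4)nc3c2)CC1` differs from compound 3 in one place: 4-ethylpiperazin-1-yl in place of piperidin-1-yl on a saturated chain carbon bound to a carbonyl carbon. This puts 4-ethylpiperazin-1-yl in place of piperidin-1-yl on a saturated chain carbon bound to a carbonyl carbon. Within the data shown here, the one measured step that bears on this change is a step that the two limits leave unreadable from compound 1 to compound 3, which gives no size to carry over. Compound 2 already carries 4-ethylpiperazin-1-yl, on a different core, and its > 50000 nM is likewise only a limit. No step beyond the scatter is therefore expected in this assay, and no direction can be given. The expected change is a step that the limit leaves unreadable from compound 3 to compound 4. Compound 4 is estimated at 60000 nM, with an expected range of 25000 nM to 100000 nM, and will most likely be reported only as a limit.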

Compound 4, half-maximal inhibitory concentration: 31900 nM
Estimate against measurement, compound 4: 1.9-fold (0.27 log units) above; measured number inside the range.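

In this assay compound 4 is the first of the compounds shown to give a number and not a limit, so this change on a saturated chain carbon bound to a carbonyl carbon now has a floor for its size: an at least 1.5-fold lower number from compound 3 to compound 4 (0.19 log units; that floor lies within the scatter) for 4-ethylpiperazin-1-yl in place of piperidin-1-yl. The neighbouring changes read alike, with an at least 1.5-fold lower number from compound 1 to compound 4 (0.19 log units; that floor lies within the scatter) for methyl in place of hydrogen on a saturated chain carbon bound to an amine nitrogen in a ring, and an at least 1.5-fold lower number from compound 2 to compound 4 (0.19 log units; that floor lies within the scatter) for 4-methylphenyl in place of 1-methyl-1H-pyrrol-2-yl on an aromatic carbon. All three floors lie within the scatter, so no real step is established, and the picture is still dominated by one feature: the limit of > 50000 nM in this assay, at which 3 of the 4 values shown sit.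

Going by these compounds, the true size of each step stays open. So does whether a morpholin-4-yl group or a dimethylamino group at this place would give a number at all.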